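Three Nitro-Thiazine Amines Measured for Plasma Exposure in Mice

The source may report more compounds than this note shows. Statements on the series, on what has been measured and on what is new or still open speak of the compounds shown alone.

Measured compounds in an ADME assay on the whole organism (Mus musculus, strain BALB/c) for pharmacokinetics, read by HPLC, with a stated time of 24 h, at a dose of 2.5 mg/kg by the intravenous route; a higher number here means more compound in the circulation at the dose given, a lower number less compound in the circulation:
Compound 1, `CC(c1cc(F)c(F)c(F)c1)N1CC2(CCN(c3nc(=O)c4cc(C(F)(F)F)cc([N+](=O)[O-])c4s3)CC2)C1`, gives 829 nM.
Compound 2, `CC(c1ccc(OC(F)(F)F)cc1)N1CC2(CCN(c3nc(=O)c4cc(C(F)(F)F)cc([N+](=O)[O-])c4s3)CC2)C1`, gives 2790 nM.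
Compound 3, `O=c1nc(N2CCN(CC3CCCCC3)CC2)sc2c([N+](=O)[O-])cc(C(F)(F)F)cc12`, gives 4040 nM.

Compound 2 stands second highest of the three numbers. Its nearest neighbour is compound 3, whose value sits within the scatter of that of compound 2, so no order between them can be claimed. For the measured compounds named here, compound 1 lies furthest away: the step of a 3.4-fold higher number from compound 1 to compound 2 (0.53 log units; beyond the scatter) is beyond the scatter and is the only measured step that bears on the change now considered.

Compound 4, `CC(c1cc(F)cc(F)c1)N1CC2(CCN(c3nc(=O)c4cc(C(F)(F)F)cc([N+](=O)[O-])c4s3)CC2)C1`, differs from compound 2 in a single place:
3,5-difluorophenyl in place of 4-(trifluoromethoxy)phenyl on a saturated chain carbon bound to an amine nitrogen in a ring and a saturated chain carbon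

Going by the values given here, the one relevant step shows that moving from a ring carrying three fluorines to the 4-(trifluoromethoxy)phenyl ring raised the number in this assay modestly. Compound 4 carries two fluorines and no trifluoromethoxy group, so a partial return toward the value of compound 1 is expected, though the two fluorinated rings are not the same and the data give no direct comparison for 3,5-difluorophenyl. Compound 4 is therefore expected to show a modest decrease, a 2.0-fold lower number from compound 2 to compound 4 (0.30 log units; within the scatter), with a wide range. The estimate for compound 4 in this assay is 1400 nM, between 600 nM and 3300 nM.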

Compound 4, maximal plasma concentration: 1340 nM
For compound 4 the middle estimate is 1.0-fold (0.02 log units) above the measured one; measured number inside the range.
By their numbers in this assay, from the lowest: compounds 1 and 4 (each within the scatter of the next); then compounds 2 and 3 (each within the scatter of the next).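

In this assay, the new step, a 2.1-fold lower number from compound 2 to compound 4 (0.32 log units; beyond the scatter), is a second step beyond the scatter at this position, so compound 2 now stands apart from two differently fluorinated rings rather than one, and the earlier rise no longer rests on the 3,4,5-trifluorophenyl ring of compound 1 alone. The step of a 1.6-fold higher number from compound 1 to compound 4 (0.21 log units; within the scatter), with hydrogen in place of fluoro on an aromatic carbon, lies within the scatter, so these two compounds cannot be ordered and the number of ring fluorines, across these two rings, shows no readable effect on the maximal plasma concentration. Nothing available accounts for why the 4-(trifluoromethoxy)phenyl compound stands apart from the two fluorinated phenyl compounds.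

The three compounds that share this core leave open how an unsubstituted phenyl, a 4-methoxyphenyl or a pyridine ring would read on the same saturated chain carbon. They also leave open whether a 3,5-difluorophenyl ring that also carried a trifluoromethoxy group would keep the number of compound 2 or fall back toward those of the two fluorinated compounds.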